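The source may report more compounds than this note shows. Statements on the series, on what has been measured and on what is new or still open speak of the compounds shown alone.

Compound 1 `FC(F)(F)c1ccccc1-c1ccc2[nH]c(C3=NOC4(CCCCC4)C3)nc2c1` gives 100%
Compound 2 `FC(F)(F)Oc1ccccc1-c1ccc2[nH]c(C3=NOC4(CCCCC4)C3)nc2c1` gives 100%
Compound 3 `FC(F)Oc1ccccc1-c1ccc2[nH]c(C3=NOC4(CCCCC4)C3)nc2c1` gives 100%

These values come from an ADME assay on microsomes from liver (Homo sapiens) for metabolic stability, with a stated time of 10 min (on this read-out lower numbers stand for a less stable compound and higher numbers for a more stable compound), and leave compound 3 level with compound 1 and compound 2. Compound 4 `CC(C)(O)c1ccccc1-c1ccc2[nH]c(C3=NOC4(CCCCC4)C3)nc2c1` has 1-hydroxy-1-methylethyl in place of difluoromethoxy on an aromatic carbon, ortho to a large group (1-hydroxy-1-methylethyl in place of difluoromethoxy on an aromatic carbon). Among the measured compounds shown here, three measured steps concern this same place (no change at the digits printed from compound 1 to compound 2 (within the scatter) and no change at the digits printed from compound 1 to compound 3 (within the scatter) and no change at the digits printed from compound 2 to compound 3 (within the scatter)), and none goes beyond the scatter. For the measured compounds named here, all three only exchange one fluorinated group for another, however, and no measured compound carries a hydroxy group there, so they guide this change only loosely. No step beyond the scatter is expected, with any shift more likely downward, since compound 3 already gives 100% and the read-out has little room upward. The estimate means a number 8 percentage points lower from compound 3 to compound 4 (within the scatter) as the expected step. For compound 4 the expected value is 92% with an estimated range from 75% to 100% as the likely span.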

Compound 4, percent of the compound remaining: 44%
Estimate against measurement, compound 4: 48 percentage points above; the measured number lies below the stated range.
By their numbers in this assay, from the lowest: compound 4; then compounds 1, 2 and 3 (each within the scatter of the next).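

In this assay, the three fluorinated groups gave no reading that separated them, so this place on an aromatic carbon, ortho to a large group, looked tolerant of change. That tolerance does not extend to 1-hydroxy-1-methylethyl, which gives a number 56 percentage points lower from compound 3 to compound 4 (beyond the scatter). The same drop appears against the other two fluorinated groups, with a number 56 percentage points lower from compound 2 to compound 4 (beyond the scatter) and a number 56 percentage points lower from compound 1 to compound 4 (beyond the scatter), so it does not depend on which of the three is replaced.

Nothing available explains the drop. The change removes fluorine and brings in a hydrogen-bond donor and a branched carbon chain together, so the compounds shown leave open which of these matters; an isopropyl group or a 2-methoxypropan-2-yl group at this place would begin to separate them.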